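Lengthening a Side Chain by One Carbon in Two Series

A few compounds are considered here, and "the series" means these few. Any claim that something is new, unique, unknown or untested is made for them only; others in the source may bear on it.

Compound 1, `CNCC(=O)Nc1cc(OC)ccc1C(=O)c1ccc(OC)c2c1OC(C)(C)C=C2`, gives 820 nM in a functional assay on MCF7 cells (Homo sapiens) for antiproliferative activity, read by MTT assay, with a stated time of 48 h; a lower number here means a stronger inhibitor, a higher number a weaker inhibitor.
Compound 2, `CCNCC(=O)Nc1cc(OC)ccc1C(=O)c1ccc(OC)c2c1OC(C)(C)C=C2`, gives 5200 nM in this assay.
Compound 3, `C=C(c1cc(OC)c(OC)c(OC)c1)c1ccc(OC)c(O)c1NC(=O)COC`, gives 560 nM in this assay.

The first two share a core and differ only by methyl in place of hydrogen on a saturated chain carbon bound to an amine nitrogen; that change produced a 6.3-fold higher number from compound 1 to compound 2 (0.80 log units; beyond the scatter), a weakening. Compound 3 has a different core, and the difference between the two cores is not broken down here. Compound 4, `C=C(c1cc(OC)c(OC)c(OC)c1)c1ccc(OC)c(O)c1NC(=O)COCC`, differs from compound 3 by methyl in place of hydrogen on a saturated chain carbon bound to an oxygen on a saturated carbon. This is the same kind of change as the earlier one, not the same: there the carbon is bound to an amine nitrogen, here to an oxygen on a saturated carbon. In this assay a weakening step of about a 2.5-fold higher number from compound 3 to compound 4 (0.40 log units; beyond the scatter) is expected, resting on a 6.3-fold higher number from compound 1 to compound 2 (0.80 log units; beyond the scatter), tempered since the surroundings differ. Compound 4 is therefore estimated at 1400 nM, likely between 500 nM and 4500 nM.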

Compound 4, half-maximal inhibitory concentration: 1050 nM
Compound 4: middle estimate off by 1.3-fold (0.12 log units), on the high side, within the range that was stated.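

In this assay, adding the methyl gives a 1.9-fold higher number from compound 3 to compound 4 (0.27 log units; within the scatter), so on this core the step cannot be told apart from ordinary variation between repeated measurements. The same kind of change therefore did not carry over at the same size from one core to the other: the same change on two cores in this assay, a 6.3-fold higher number (0.80 log units; beyond the scatter) from compound 1 to compound 2 and a 1.9-fold higher number (0.27 log units; within the scatter) from compound 3 to compound 4, 3.4-fold (0.53 log units) apart, beyond the scatter of two such steps

This comparison rests on a single pair for each core, and the changed carbon is bound to an amine nitrogen in one pair and to an oxygen on a saturated carbon in the other, so the core alone cannot be named as what sets the size of the step.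

The compounds shown leave open how an amine chain would respond to the same change on the core of compound 3. They also leave open how a longer chain would behave on either core.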